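Notes on compound 4: pyrazol-1-yl for triazol-1-yl

A few compounds are considered here, and "the series" means these few. Any claim that something is new, unique, unknown or untested is made for them only; others in the source may bear on it.

Compound 1 `CCC(C)(C)Cc1c[nH]c(CCc2ccc(-c3cccc(N)n3)cc2)n1` gives 3.9 nM in a functional assay on HEK293 cells for agonist activity at Bombesin receptor subtype-3 (Mus musculus), read by luminescence and calcium flux, with a stated time of 10 min; a lower number here means that less compound is needed, a higher number that more compound is needed for the effect. Compound 2 `CCC(C)(C)Cc1c[nH]c(CCc2ccc(N3CCCCC3)cc2)n1` gives 28 nM, and compound 3 `CCC(C)(C)Cc1c[nH]c(CCc2ccc(-n3ccnn3)cc2)n1` gives 57 nM, the highest number of the three: the steps of a 15-fold higher number from compound 1 to compound 3 (1.16 log units; beyond the scatter) and a 2.0-fold higher number from compound 2 to compound 3 (0.31 log units; beyond the scatter) both lie beyond the scatter, as does a 7.2-fold higher number from compound 1 to compound 2 (0.86 log units; beyond the scatter). Compound 4 `CCC(C)(C)Cc1c[nH]c(CCc2ccc(-n3cccn3)cc2)n1` differs from compound 3 as follows: 1H-pyrazol-1-yl in place of 1H-1,2,3-triazol-1-yl on an aromatic carbon. Within the data shown here, no measured step swaps one five-membered aromatic ring for another; the steps recorded so far only show that compound 3 is the weakest of the three and give no direction for this particular change. The step is therefore expected to stay within the scatter, a 1.4-fold lower number from compound 3 to compound 4 (0.15 log units; within the scatter). Compound 4 is estimated at 40 nM in this assay, within 15 nM to 120 nM.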

Compound 4, half-maximal effective concentration: 9 nM
Estimate against measurement, compound 4: 4.4-fold (0.65 log units) above, and the stated range ends above it.
By their numbers in this assay, from the lowest: compound 1; then compound 4; then compound 2; then compound 3.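

At the aromatic carbon para to a large group, the five-membered ring is not interchangeable: replacing a ring nitrogen with carbon gives a 6.3-fold lower number from compound 3 to compound 4 (0.80 log units; beyond the scatter). The 1H-pyrazol-1-yl also outperforms piperidin-1-yl, with a 3.1-fold lower number from compound 2 to compound 4 (0.49 log units; beyond the scatter), but does not match 6-aminopyridin-2-yl, with a 2.3-fold higher number from compound 1 to compound 4 (0.36 log units; beyond the scatter).

No measurement available here explains the size of these steps. As far as these compounds go, it remains open whether 1H-imidazol-1-yl, or a 1H-pyrazol-1-yl carrying an amine or a methyl group, would bring the number closer to that of compound 1.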